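From nitrile to acetyl on the outer phenyl ring

The source may hold more compounds than are shown below. What is called first, only, known or untested is meant among the compounds shown, and "the series" means these compounds.

Values in a functional assay on HCT-116 cells (Homo sapiens) for antiproliferative activity, read by MTT assay, with a stated time of 72 h; on this read-out higher numbers stand for weaker inhibition and lower numbers for stronger inhibition:
- compound 1 `O=C(CCc1cccc2c1B(O)OC2)Nc1cccc(Br)c1`: 1400 nM
- compound 2 `COc1cc(OC)cc(-c2cccc(NC(=O)CCc3cccc4c3B(O)OC4)c2)c1`: 53 nM
- compound 3 `N#Cc1cccc(-c2cccc(NC(=O)CCc3cccc4c3B(O)OC4)c2)c1`: 140 nM

Compound 3, at 140 nM, has the second highest of the three numbers, lying under compound 1 and over compound 2. The next compound to be tested is compound 4 `CC(=O)c1cccc(-c2cccc(NC(=O)CCc3cccc4c3B(O)OC4)c2)c1`, which has acetyl in place of cyano on an aromatic carbon, meta to a large group: acetyl in place of cyano on an aromatic carbon. The change turns 3-cyanophenyl into 3-acetylphenyl.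

Going by the values given here, three measured steps bear on this. The two that replace bromo are the largest, a 26-fold lower number from compound 1 to compound 2 (1.42 log units; beyond the scatter) and a 10-fold lower number from compound 1 to compound 3 (1.00 log units; beyond the scatter). Compound 4 keeps the aryl group gained in those steps, however, so neither size should carry over. Among the compounds with values here, the closest precedent is the exchange of one substituted phenyl for another, a 2.6-fold higher number from compound 2 to compound 3 (0.42 log units; beyond the scatter), which is a much smaller move. Within the data shown here, it is also the only such exchange measured, so it gives little guidance on direction.

A small change in this assay is therefore expected, probably none beyond the scatter. The estimated step is a 1.3-fold lower number from compound 3 to compound 4 (0.10 log units; within the scatter). For compound 4 the expected value is 110 nM, with an estimated range of 45 nM to 270 nM.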

Compound 4, half-maximal inhibitory concentration: 86 nM
Beside the measured number, compound 4's estimate is 1.3-fold (0.11 log units) above it, and the stated range covers the measured number.
By their numbers in this assay, from the lowest: compounds 2, 4 and 3 (each within the scatter of the next, the first and the last beyond it); then compound 1.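

In this assay, the step from cyano to acetyl at this place, a 1.6-fold lower number from compound 3 to compound 4 (0.21 log units; within the scatter), stays within the scatter, so the 3 heavy atoms of acetyl read no differently here from the 2 of cyano. The comparison with the dimethoxy-bearing aryl group, a 1.6-fold higher number from compound 2 to compound 4 (0.21 log units; within the scatter), is also within the scatter, so compound 4 cannot be told apart from either of its neighbours, even though compound 2 and compound 3 are separated beyond it. Replacing bromo with 3-acetylphenyl gives a 16-fold lower number from compound 1 to compound 4 (1.21 log units; beyond the scatter), the third aryl replacement to clear the scatter, so all three aryl compounds now stand well apart from compound 1 whichever substituent the outer ring carries.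

Nothing shown here accounts for why cyano and acetyl read alike in these cells. The compounds also leave open how far this tolerance extends, since a primary amine, a carboxylic acid, a longer acyl chain such as butanoyl, or an unsubstituted phenyl in place of 3-acetylphenyl would each test whether the result holds beyond nitrile and ketone groups.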